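Amide variations on the shared core: cytotoxicity notes

A few compounds are considered here, and "the series" means these few. Any claim that something is new, unique, unknown or untested is made for them only; others in the source may bear on it.

Compound 1 `COc1ccc(-c2cnc(NC(=O)c3ccccc3OC)n2C)cc1` gives > 100000 nM in a toxicity assay on THP-1 cells (Homo sapiens) for inhibition (a lower number here means that less compound is tolerated, a higher number that more compound is tolerated), a limit of the assay.
Compound 2 `COc1ccc(-c2cnc(NC(=O)c3cccc(Br)c3)n2C)cc1` gives > 100000 nM in this assay, again a limit.
Compound 3 `COc1ccc(-c2cnc(NC(=O)c3cnco3)n2C)cc1` gives > 100000 nM in this assay, also a limit.

Compound 3 thus stands on a limit only, and the two other values shown are limits as well (the limit of > 100000 nM in this assay, at which 3 of the 3 values shown sit). The steps among the measured compounds, a step that the two limits leave unreadable from compound 1 to compound 2, a step that the two limits leave unreadable from compound 1 to compound 3 and a step that the two limits leave unreadable from compound 2 to compound 3, are therefore all unreadable in size.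

Compound 4 `COc1ccc(-c2cnc(NC(=O)c3ccc(Cl)cc3)n2C)cc1` is not yet measured. It differs from compound 3 by 4-chlorophenyl in place of 1,3-oxazol-5-yl on a carbonyl carbon. Among the measured compounds shown here, the steps that bear on this change are those into and out of compound 3, both unreadable; nothing measured so far distinguishes any amide substituent in this assay. The expectation is therefore that the step of a number no higher from compound 3 to compound 4 (the limit leaves the size open) will not be readable beyond the scatter, with the assay most likely reporting a limit again. Compound 4 is estimated to give 100000 nM in this assay, within a range of 30000 nM to 300000 nM.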

Compound 4, half-maximal cytotoxic concentration: > 100000 nM
Compound 4: no number, only a limit; the forecaster's own chance of this, stated with the estimate: 80%; the middle value lies on the limit itself.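

No step can be read among compound 1, compound 2, compound 3 and compound 4, since each gives only a limit in this assay. The compounds shown leave open the actual cytotoxic concentration of each and whether any amide substituent stands apart from the others: the limit of > 100000 nM in this assay, at which 4 of the 4 values shown sit.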